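Moving the bromine on the hydroxyphenyl amide

The compounds below may be only part of what the source reports. "The series", "measured", "known", "first", "only" and "open" are said of these compounds alone.

Measured in an ADME assay on HEK293 cells (Homo sapiens) for cytotoxicity, read by reporter gene assay and resazurin assay, with a stated time of 48 h; a lower number here means that less compound is tolerated, a higher number that more compound is tolerated:
- compound 1 `O=C(Nc1ccc(Sc2nc3ccccc3s2)c(Cl)c1)c1cccc(Br)c1O`: 64000 nM
- compound 2 `O=C(Nc1ccc(Sc2nc3ccccc3s2)cc1)c1cccc(Br)c1O`: 71000 nM

Only these two numbers are available, and compound 1 lies within the scatter of compound 2, so neither stands apart from the other. The next comparison is compound 3 `O=C(Nc1ccc(Sc2nc3ccccc3s2)c(Cl)c1)c1cc(Br)ccc1O`, which has 5-bromo-2-hydroxyphenyl in place of 3-bromo-2-hydroxyphenyl on a carbonyl carbon. The two share the same atoms, joined differently.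

Going by the values given here, one measured step bears on this, and only indirectly. That step, a 1.1-fold higher number from compound 1 to compound 2 (0.05 log units; within the scatter), puts hydrogen in place of chloro on an aromatic carbon, so it concerns a different change. Among the compounds with values here, no measured pair tests the bromine placement, and the data give no direction for it. The small size of that single step offers weak support for a flat response in this assay, so no step beyond the scatter is expected, in either direction.

The expected step is a 1.1-fold lower number from compound 1 to compound 3 (0.03 log units; within the scatter). For compound 3 the estimated value is 60000 nM, with an expected range from 28000 nM to 110000 nM.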

Compound 3, half-maximal cytotoxic concentration: 45000 nM
Compound 3: middle estimate off by 1.3-fold (0.12 log units), on the high side; measured number inside the range.
By their numbers in this assay, from the lowest: compounds 3, 1 and 2 (each within the scatter of the next).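

In this assay, going by these compounds alone, this is the first direct reading on the bromine placement: with the same atoms joined differently, 5-bromo-2-hydroxyphenyl in place of 3-bromo-2-hydroxyphenyl on a carbonyl carbon gives a 1.4-fold lower number from compound 1 to compound 3 (0.15 log units; within the scatter), so compound 3 and compound 1 cannot be told apart in this read-out. The earlier step concerned only the chloro group, whereas this one shows that the response at the carbonyl-bound ring also stays within the scatter for this one relocation of the bromine, on the core of compound 1. No measurement available here accounts for this step.

Still open, going by these compounds, is whether the same relocation stays within the scatter on the core of compound 2, which carries hydrogen in place of chloro. Also open, on these data alone, is how this assay responds to a larger change at this position, such as an amine or a carboxylic acid in place of the bromine, or a methoxy group in place of the hydroxy group.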